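Mirroring One Stereocentre in a Cytotoxic Amide

The source may hold more compounds than are shown below. What is called first, only, known or untested is meant among the compounds shown, and "the series" means these compounds.

Measured compounds:
compound 1 `COc1cc(NC(=O)[C@H]2CSC(c3ccccc3)=N2)cc(OC)c1OC`: 3400 nM
compound 2 `CCCCCCCCCCCCCCCCC(=O)c1csc(-c2ccccc2)n1`: > 20000 nM

Going by the values given here, in a functional assay on PPC-1 cells (Homo sapiens) for cytotoxicity, read by sulforhodamine B assay, with a stated time of 48 h (a higher number here means a weaker inhibitor, a lower number a stronger inhibitor), compound 1 gives 3400 nM, the only true number available so far. Compound 2 reaches only a limit of the assay, > 20000 nM. That leaves compound 1 with no measured neighbour to be ranked against.

The next compound is compound 3 `COc1cc(NC(=O)[C@@H]2CSC(c3ccccc3)=N2)cc(OC)c1OC`. Its change is the subtlest kind: the two compounds have the same atoms and bonds and differ only in configuration as drawn: 1 of 1 stereo elements differ; a stereocentre at a saturated ring carbon is drawn S in compound 1 and R in compound 3. Nothing is added or removed, so the two compounds are mirror forms at that one carbon.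

Among the compounds with values here, no measured pair here shows what such an inversion does in this assay, so any expectation is uncertain. Changes in configuration alone can be silent or can matter a great deal. With no evidence for either direction, the working expectation is a change no larger than the usual scatter, while leaving room for a real loss or gain.

The estimate is anchored on compound 1 at 3400 nM. The expected change is a 1.0-fold higher number from compound 1 to compound 3 (0.01 log units; within the scatter). For compound 3 the estimated value is 3500 nM, with an expected range from 1200 nM to 10000 nM.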

Compound 3, half-maximal inhibitory concentration: 5300 nM
Compound 3: the middle estimate sits 1.5-fold (0.18 log units) below what was measured, and the stated range covers the measured number.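

In this assay, inverting the stereocentre at the saturated ring carbon gives a 1.6-fold higher number from compound 1 to compound 3 (0.19 log units; within the scatter). Going by these compounds alone, this is the first pair of compounds that can be read side by side, and it isolates a single variable, with no group entering or leaving: the fact that compounds 1 and 3 differ only in the configuration as drawn. At this carbon, therefore, the S and R forms cannot be told apart by this read-out, so this one pair gives no sign that the cells favour either mirror form.

One pair says nothing about whether the two mirror forms would stay this close on a different scaffold, for example if an amine or a carboxylic acid replaced one of the methoxy groups of compound 1, or whether the same would hold in any read-out other than this assay. It also leaves open which parts of the shared structure of compound 1 and compound 3 matter for the value, since a change at any other place in either compound has no measured neighbour to be compared with.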